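The source may hold more compounds than are shown below. What is called first, only, known or untested is meant among the compounds shown, and "the series" means these compounds.

Three compounds have been measured in a functional assay on the whole organism with Mus musculus as the target, with a stated time of 15 min; on this read-out lower numbers stand for an effect already at smaller amounts and higher numbers for an effect only at larger amounts of compound:

Compound 1 `Cc1sc2c(F)cccc2c1C1C=CN=CN1` gives 10 mg/kg.
Compound 2 `Cc1sc2c(c1C1C=CN=CN1)CCC2` gives 10 mg/kg.
Compound 3 `Cc1sc2cccc(F)c2c1C1C=CN=CN1` gives 3 mg/kg.

Compound 1 and compound 2 show the same number at the digits printed, and together they stand at the highest value of the three. Compound 3 stands at a lower number, and that gap from compound 1 lies beyond the usual scatter of this assay. No pair among these three differs in only one place, so none of these gaps can be tied to a single structural change.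

Compound 4 `Cc1sc2c(Cl)cccc2c1C1C=CN=CN1` has not yet been measured. Compared with compound 1, the difference is chloro in place of fluoro on an aromatic carbon. Among the measured compounds shown here, no measured pair here shows what swapping one halogen for another does on this core, so the expectation for compound 4 rests only on the value of compound 1. Since nothing in the data points in either direction, the expected step from compound 1 to compound 4 in this assay is a 1.3-fold lower number from compound 1 to compound 4 (0.10 log units; within the scatter), that is, no change beyond the scatter. Compound 4 is therefore estimated at 8 mg/kg, with a range from 2.5 mg/kg to 30 mg/kg.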

Compound 4, minimum effective dose: 30 mg/kg
Beside the measured number, compound 4's estimate is 3.8-fold (0.57 log units) below it; measured number inside the range.
By their numbers in this assay, from the lowest: compound 3; then compounds 1 and 2 (each within the scatter of the next); then compound 4.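

Among the compounds shown here, this is the first pair here that differs in one place only, so it is the first change that can be read on its own. In this assay the step of a 3.0-fold higher number from compound 1 to compound 4 (0.48 log units; beyond the scatter) is modest but beyond the usual scatter, which shows that the choice of halogen on this aromatic carbon affects how much compound is needed for an effect. Fluoro and chloro match in what can be counted here, with one heavy atom each and no hydrogen-bond donors or acceptors, and no measurement at hand explains the step.

From the compounds shown here alone, it remains open whether bromo, methoxy or an amine on this same carbon would continue the trend or reverse it. Also open, going by these compounds, is whether chloro in place of the fluoro of compound 3 would give a step of similar size.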